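Adding a second methoxy to the hydrazide aryl ring

A few compounds are considered here, and "the series" means these few. Any claim that something is new, unique, unknown or untested is made for them only; others in the source may bear on it.

Measured compounds:
- compound 1, `COc1cccc(C(=O)NNC(=O)C2(C(=O)N[C@H]3CC(=O)OC3O)CCC2)c1`: 2200 nM
- compound 2, `COc1cccc(C(=O)NNC(=O)C2(C(=O)N[C@H]3CC(=O)OC3O)CCCC2)c1`: 1170 nM
- compound 3, `COc1cccc(C(=O)NNC(=O)C2(C(=O)N[C@H]3CC(=O)OC3O)CCCCC2)c1`: 1800 nM

Of the compounds shown here, three have been tested in an assay on isolated protein for inhibition of Caspase-8 (Homo sapiens); on this read-out lower numbers stand for stronger inhibition and higher numbers for weaker inhibition. They share one core and differ only in the size of the carbocycle at its centre: compound 1 carries the smallest ring, compound 2 a ring one carbon larger, and compound 3 the largest. In this assay compound 1 gives 2200 nM, compound 2 gives 1170 nM and compound 3 gives 1800 nM. The number for compound 3 sits between the other two, and its gaps to compound 1 and to compound 2 both fall within the usual scatter of repeated measurements, so none of the three can be called stronger or weaker than another on this evidence.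

Compound 4, `COc1cccc(OC)c1C(=O)NNC(=O)C1(C(=O)N[C@H]2CC(=O)OC2O)CCCCC1`, keeps the largest carbocycle of compound 3 and changes the aryl group on the hydrazide: 2,6-dimethoxyphenyl in place of 3-methoxyphenyl on a carbonyl carbon. Among the compounds with values here, no measured pair shows the effect of this kind of change, so there is nothing to anchor a direction. The expectation for this assay is a step of no more than the scatter, in either direction, giving an estimated 1.1-fold higher number from compound 3 to compound 4 (0.05 log units; within the scatter). Compound 4 is therefore expected to give about 2000 nM, with a likely range from 800 nM to 5000 nM.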

Compound 4, half-maximal inhibitory concentration: 300 nM
The estimate for compound 4 lay 6.7-fold (0.82 log units) above the measured number; measured number outside the range, below it.
By their numbers in this assay, from the lowest: compound 4; then compounds 2, 3 and 1 (each within the scatter of the next).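

In this assay the swap to 2,6-dimethoxyphenyl in place of 3-methoxyphenyl on a carbonyl carbon gives a 6.0-fold lower number from compound 3 to compound 4 (0.78 log units; beyond the scatter) and thus moves the number by more than the usual scatter. Within the data shown here, the three earlier compounds, which differ only in the size of the carbocycle, could not be told apart, so the aryl group on the hydrazide is the first place in this set where a single change clearly shifts the read-out. The two aryl groups differ both in how many methoxy groups they carry and in where those groups sit on the ring, so this one pair cannot show which of the two differences matters.

Going by these compounds, it remains open whether the same aryl group would lower the number equally on the smaller carbocycles of compound 1 and compound 2, and whether a plain phenyl or a ring carrying chlorine atoms in place of the methoxy groups would behave in the same way. Nothing in the available data bears on why this step occurs.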